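A Shorter Chain on a Polyhydroxylated Piperidine Core

The source may report more compounds than this note shows. Statements on the series, on what has been measured and on what is new or still open speak of the compounds shown alone.

Compound 1 `CCC[C@@H]1NC[C@@H](O)[C@@H](O)[C@H](O)[C@H]1O` has no result in an assay for inhibition of beta-glucuronidase (Bos taurus), tested at 1000 uM; on this read-out higher numbers stand for more inhibition at the one concentration tested (going by the name of the read-out) and lower numbers for less inhibition: for compound 1 the value is given as "not determined" (no result reported), so it stands at no single number. A related compound, compound 2 `CC[C@H]1NC[C@@H](O)[C@@H](O)[C@H](O)[C@H]1O`, gives 0.1% in this assay, which amounts to essentially no inhibition at the concentration tested. Compound 3 `CC[C@@H]1NC[C@@H](O)[C@@H](O)[C@H](O)[C@H]1O` is reached from compound 1 by the change (hydrogen in place of methyl on a saturated chain carbon, two bonds along the chain from a saturated ring carbon). For the measured compounds named here, with no measured pair of this kind available, no step beyond the usual scatter is expected in this assay in either direction. Compound 3 is expected to give about 2%, most likely between 0% and 15%.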

Compound 3, a percentage reported as inhibition, at one concentration (the size of the read-out at that concentration, not a potency): 0.1%
Beside the measured number, compound 3's estimate is 1.9 percentage points above it, within the range that was stated.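

Changing the configuration at one stereocentre on a saturated ring carbon gives no change at the digits printed from compound 2 to compound 3 (within the scatter) in this assay. This comparison tests configuration alone: the fact that compounds 2 and 3 differ only in the configuration as drawn

With an ethyl chain, then, neither drawn configuration shows meaningful inhibition at the one concentration tested, so this stereocentre has no visible effect on this read-out. Still open, as far as these compounds go, is whether a longer chain, or an amine or a carboxylic acid on the chain, would bring inhibition. Also open, from the compounds shown here alone, is whether configuration at this carbon would matter in a compound that does inhibit the enzyme.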